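Series notes: the step from compound 3 to compound 4

This account rests on a few compounds, and the source may have more. Where it says the series, first, only, none or still open, it means among the compounds named here.

The shared core of compound 1 `NC(=O)/C=C/c1ccncc1-c1ccc2ccccc2c1` carries a 2-carbamoylethenyl group; in a functional assay on HCT-116 cells (Homo sapiens) for inhibition, read by MTT assay, with a stated time of 72 h (on this read-out higher numbers stand for weaker inhibition of growth and lower numbers for stronger inhibition of growth), compound 1 gives 12100 nM. Compound 2 `COC1CN(C(=O)/C=C/c2ccncc2-c2ccc3[nH]ncc3c2)C1` belongs to the same set, but in this assay compound 2 has "not determined" (no result reported). Compound 3 `O=C(O)CCc1ccncc1-c1ccc2ccccc2c1` carries 2-carboxyethyl in place of 2-carbamoylethenyl on an aromatic carbon. In this assay compound 3 reaches only a limit, > 30000 nM. Compound 3 therefore stands at the weak end of the numbers shown, sitting at the limit of > 30000 nM in this assay, at which 1 of the 3 values shown sits. Within the data shown here, the one measured step that bears on the change, an at least 2.4-fold higher number from compound 1 to compound 3 (0.39 log units; beyond the scatter), is at least modest.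

Compound 4 `O=C(/C=C/c1ccncc1-c1ccc2ccccc2c1)NC1CC1` is still to be measured. It differs from compound 3 thus: 2-(cyclopropylcarbamoyl)ethenyl in place of 2-carboxyethyl on an aromatic carbon. Compound 4 thus carries a 2-(cyclopropylcarbamoyl)ethenyl group where compound 1 carries 2-carbamoylethenyl. Because an at least 2.4-fold higher number from compound 1 to compound 3 (0.39 log units; beyond the scatter) ran toward weaker growth inhibition, a return to an ethenyl amide is expected to run the other way. In this assay the step of an at least 3.7-fold lower number from compound 3 to compound 4 (0.57 log units; beyond the scatter) is expected to lower the number beyond the scatter. In this assay compound 4 is estimated at 8000 nM, within 2500 nM to 25000 nM.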

Compound 4, concentration for 50% growth inhibition: 6180 nM
Compound 4: the middle estimate sits 1.3-fold (0.11 log units) above what was measured, within the range that was stated.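

In this assay the 2-(cyclopropylcarbamoyl)ethenyl group, opposite the ring nitrogen, gives a single number where 2-carboxyethyl does not, with an at least 4.8-fold lower number from compound 3 to compound 4 (0.68 log units; beyond the scatter). Compound 3 holds only a limit, so this step has a floor and no exact size: the limit of > 30000 nM in this assay, at which 1 of the 4 values shown sits. Cyclopropyl in place of hydrogen on the amide nitrogen adds a three-membered ring without leaving the scatter, with a 2.0-fold lower number from compound 1 to compound 4 (0.29 log units; within the scatter).

The ethenyl link and the amide change together between the acid and the amide, and a 2-carboxyethenyl or a 2-carbamoylethyl group at this position would be needed to tell their shares apart. As far as these compounds go, whether a longer alkyl chain or an amine-bearing chain on the amide nitrogen would move the number beyond the scatter also stays open.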